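The source may hold more compounds than are shown below. What is called first, only, known or untested is meant among the compounds shown, and "the series" means these compounds.

Compound 3, `CO/N=C/c1c(Cl)n(C2O[C@H](CO)[C@@H](O)[C@H]2O)c2cc(Cl)c(Cl)cc12`, stands at the top of the three numbers in a functional assay on KB cells (Homo sapiens) for cytotoxicity, read by spectrophotometry and crystal violet staining; a lower number here means a stronger inhibitor, a higher number a weaker inhibitor: compound 3 gives 70000 nM, compound 2, `COC(=N)c1c(Cl)n(C2O[C@H](CO)[C@@H](O)[C@H]2O)c2cc(Cl)c(Cl)cc12`, gives 50000 nM, and compound 1, `CC(=O)N/N=C/c1c(Cl)n(C2O[C@H](CO)[C@@H](O)[C@H]2O)c2cc(Cl)c(Cl)cc12`, gives 9000 nM. The gap a 1.4-fold higher number from compound 2 to compound 3 (0.15 log units; within the scatter) lies within the scatter, whereas a 7.8-fold higher number from compound 1 to compound 3 (0.89 log units; beyond the scatter) and a 5.6-fold higher number from compound 1 to compound 2 (0.74 log units; beyond the scatter) both lie beyond it. Compound 4, `N/C(S)=N/N=C/c1c(Cl)n(C2O[C@H](CO)[C@@H](O)[C@H]2O)c2cc(Cl)c(Cl)cc12`, differs from compound 3 by a group of 4 heavy atoms (1 carbon, 2 nitrogen, 1 sulfur; no ring) in place of a group of 2 heavy atoms (1 carbon, 1 oxygen; no ring), on a double-bonded nitrogen. The step that bears most directly on this is the one in which methoxy replaced acetamido on the same double-bonded nitrogen, a 7.8-fold higher number from compound 1 to compound 3 (0.89 log units; beyond the scatter); compound 4 carries on that nitrogen a group that, like acetamido, brings hydrogen-bond donors, so a return toward the number of compound 1 is expected in this assay. Going by the values given here, the expected step is a 7.0-fold lower number from compound 3 to compound 4 (0.85 log units; beyond the scatter), downward and beyond the scatter, though the group in compound 4 is not the one in compound 1, so the size is uncertain. Compound 4 is therefore estimated at 10000 nM, with a range from 3000 nM to 35000 nM.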

Compound 4, half-maximal inhibitory concentration: 65000 nM
Compound 4: the middle estimate sits 6.5-fold (0.81 log units) below what was measured; the measured number lies above the stated range.
By their numbers in this assay, from the lowest: compound 1; then compounds 2, 4 and 3 (each within the scatter of the next).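

In this assay, putting the group of compound 4 on the double-bonded nitrogen in place of methoxy leaves the number where it was (a 1.1-fold lower number from compound 3 to compound 4 (0.03 log units; within the scatter)), so hydrogen-bond donors on this nitrogen do not by themselves bring back the level of compound 1. Compound 4 stays apart from compound 1 (a 7.2-fold higher number from compound 1 to compound 4 (0.86 log units; beyond the scatter)) and cannot be told from compound 2 (a 1.3-fold higher number from compound 2 to compound 4 (0.11 log units; within the scatter)), which leaves acetamido as the only group among these compounds that stands out. Nothing available here explains what separates acetamido from the group in compound 4.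

On these data alone, what a hydroxyl, a plain amino group or the longer propionamido would give on this nitrogen remains open. So does whether the carbonyl of acetamido or its amide hydrogen sets compound 1 apart.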